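The source may report more compounds than this note shows. Statements on the series, on what has been measured and on what is new or still open speak of the compounds shown alone.

Compound 3 `CCOC(=O)CCCCCOc1cccc(CN(C(=O)c2ccc(-c3cnc(OC)nc3OC)cc2)C(C)C)c1` is one of three compounds tested in an ADME assay on HepG2 cells (Homo sapiens) for cytotoxicity, read by CellTiter-Glo and resazurin assay, with a stated time of 72 h (a higher number here means that more compound is needed for the effect, a lower number that less compound is needed), and none of the three yields a number. In this assay compound 3 gives > 26000 nM, which is a limit of the assay rather than a measured value. Compound 1 `CC(C)N(Cc1cccc(OCCCCCC(=O)O)c1)C(=O)c1ccc(-c2ccoc2)cc1` likewise reaches only the limit of > 26000 nM in this assay. Compound 2 `CCOC(=O)CCCCCOc1cccc(CN(C(=O)c2ccc(-c3cccc4ccccc34)cc2)C(C)C)c1` gives > 26000 nM in this assay, again a limit. All three thus sit together at the limit of > 26000 nM in this assay, at which 3 of the 3 values shown sit, so no difference between them can be read. Going by the values given here, the one measured step between close neighbours, a step that the two limits leave unreadable from compound 2 to compound 3, swaps naphthalen-1-yl for 2,4-dimethoxypyrimidin-5-yl on an aromatic carbon, yet both of its ends rest at the limit and its size stays hidden.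

Compound 4 `CCOC(=O)CCCCCOc1cccc(CN(C(=O)c2ccc(-c3ccoc3)cc2)C(C)C)c1` differs from compound 3 by furan-3-yl in place of 2,4-dimethoxypyrimidin-5-yl on an aromatic carbon: a smaller five-membered aromatic ring with one hetero atom takes the place of the six-membered ring with two hetero atoms, on an aromatic carbon of the six-membered carbon-only ring, para to a large group. The same furan-3-yl group appears in compound 1, which also reached only the limit. Among the compounds with values here, nothing among the measured compounds points to a step beyond the scatter; the expected shift is a step that the limit leaves unreadable from compound 3 to compound 4, none beyond the scatter. For compound 4 the estimated value in this assay is 40000 nM, within a range from 20000 nM to 90000 nM, most likely reported once more as a limit.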

Compound 4, half-maximal effective concentration: > 26000 nM
Compound 4 gave a limit, no number (the forecaster's own chance of this, stated with the estimate: 85%); the middle value lies beyond the limit too.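

Compound 4 joins compound 1, compound 2 and compound 3 at a limit in this assay, so none of the steps linking compound 4 to those three can be read: the limit of > 26000 nM in this assay, at which 4 of the 4 values shown sit.

The compounds shown leave open at what concentration, if any, these four would affect the cells, and whether swapping the aromatic group or the ethyl changes that concentration.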